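The compounds below may be only part of what the source reports. "The series", "measured", "known", "first", "only" and "open" are said of these compounds alone.

Measured in a functional assay on MCF7 cells (Homo sapiens); on this read-out higher numbers stand for weaker inhibition and lower numbers for stronger inhibition:
- compound 1 `COc1cc(NC(C)CCCNC(=O)NCCCO)c2ncccc2c1`: 31000 nM
- compound 2 `COc1cc(NC(C)CCCNC(=O)NC(CO)(CO)CO)c2ncccc2c1`: 24000 nM
- compound 3 `COc1cc(NC(C)CCCNC(=O)NCCNC(=O)NCCCC(C)Nc2cc(OC)cc3cccnc23)c2ncccc2c1`: 31000 nM

All three values lie within the scatter of one another, so compound 2 stands level with the other two. Compound 4 `COC(=O)NCCCC(C)Nc1cc(OC)cc2cccnc12` carries methoxy in place of (2-hydroxy-1,1-bis(hydroxymethyl)ethyl)amino on a carbonyl carbon. Within the data shown here, the only measured step, a 1.3-fold lower number from compound 1 to compound 2 (0.11 log units; within the scatter), stays within the scatter, and no measured compound has methoxy on that carbonyl carbon. The evidence is therefore thin, and the range is kept wide. In this assay the expected change is a 1.0-fold higher number from compound 2 to compound 4 (0.02 log units; within the scatter), with no shift beyond the scatter expected. The estimate for compound 4 is 25000 nM, with an expected range of 10000 nM to 60000 nM.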

Compound 4, half-maximal inhibitory concentration: > 100000 nM
Compound 4 ended at the assay's limit (the forecaster's own chance of this, stated with the estimate: 10%); middle value at least 4.0-fold (0.60 log units) from the limit.
By their numbers in this assay, from the lowest: compounds 2, 1 and 3 (each within the scatter of the next). At a limit, above all of these: compound 4.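

Compound 4 stands at a limit of the assay and not at a number in this assay: the limit of > 100000 nM in this assay, at which 1 of the 4 values shown sits.

Among these compounds, this gives the first change at the carbonyl carbon that lies beyond the scatter, with an at least 4.1-fold higher number from compound 2 to compound 4 (0.61 log units; beyond the scatter) and an at least 3.2-fold higher number from compound 1 to compound 4 (0.50 log units; beyond the scatter). Both amino groups, (3-hydroxypropyl)amino and (2-hydroxy-1,1-bis(hydroxymethyl)ethyl)amino, hold the read-out within the scatter of each other, whereas methoxy in their place does not.

On these data alone, the true size of both steps stays open, as each is bounded on one side only. As far as these compounds go, whether a plain methylamino group or an ethoxy group on that carbonyl carbon stays level with compound 1 and compound 2 also stays open.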